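This account rests on a few compounds, and the source may have more. Where it says the series, first, only, none or still open, it means among the compounds named here.

Among the compounds with values here, compound 1 `Cn1c(-c2ccc(NC(=O)CSc3nc4ccccc4o3)cc2)nc(-c2ccccc2)c1-c1ccccc1` is the stronger of the two compounds measured so far. In a functional assay on MCF7 cells (Homo sapiens) for cytotoxicity, read by MTT assay, with a stated time of 24 h, tested at 16 ug/mL (on this read-out lower numbers stand for a weaker effect and higher numbers for a stronger effect at the one concentration tested), compound 1 gives 56%, the higher of the two numbers recorded. Within the data shown here, its only measured neighbour, compound 2 `Cc1ccc2oc(SCC(=O)Nc3ccc(-c4nc(-c5ccccc5)c(-c5ccccc5)n4C)cc3)nc2c1`, gives 40.3% in this assay, and the step of a number 15.7 percentage points lower from compound 1 to compound 2 (beyond the scatter), a methyl in place of hydrogen on an aromatic carbon of the group that leaves in the next change, lies beyond the scatter.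

Compound 3 `Cn1c(-c2ccc(NC(=O)CN3CCN(c4ccccc4)CC3)cc2)nc(-c2ccccc2)c1-c1ccccc1` departs from compound 1 by 4-phenylpiperazin-1-yl in place of (1,3-benzoxazol-2-yl)sulfanyl on a saturated chain carbon bound to a carbonyl carbon. Among the measured compounds shown here, no measured step touches this part of the molecule directly; the single known step, a number 15.7 percentage points lower from compound 1 to compound 2 (beyond the scatter), concerns a small change on the aromatic ring of the (1,3-benzoxazol-2-yl)sulfanyl group and shows only that the read-out in this assay moves by a modest amount when that group is altered. Exchanging the whole group for 4-phenylpiperazin-1-yl is a larger change, and the direction cannot be read from the data. For compound 3 the expected step is therefore a number 14 percentage points lower from compound 1 to compound 3 (beyond the scatter), a modest loss with wide uncertainty in both directions. Compound 3 is estimated at 42%, within 18% to 66% in this assay.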

Compound 3, a percentage reported as activity, at one concentration (the size of the read-out at that concentration, not a potency): 59.6%
Estimate against measurement, compound 3: 17.6 percentage points below, within the range that was stated.
By their numbers in this assay, from the lowest: compound 2; then compounds 1 and 3 (each within the scatter of the next).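

In this assay, the saturated chain carbon bound to a carbonyl carbon accepts 4-phenylpiperazin-1-yl in place of (1,3-benzoxazol-2-yl)sulfanyl with a number 3.6 percentage points higher from compound 1 to compound 3 (within the scatter), so among these compounds the read-out does not depend on keeping the (1,3-benzoxazol-2-yl)sulfanyl group. Against the methylated group, 4-phenylpiperazin-1-yl in place of (5-methyl-1,3-benzoxazol-2-yl)sulfanyl gives a number 19.3 percentage points higher from compound 2 to compound 3 (beyond the scatter), which leaves compound 2 as the only one of the three set apart from the others beyond the scatter. No measurement is available that bears on why these groups read as they do.

The compounds shown leave open which part of 4-phenylpiperazin-1-yl carries the result, a question that a plain piperazin-1-yl, a 4-methylpiperazin-1-yl or a morpholin-4-yl group at the same place would address. Going by these compounds, it also remains open whether a methyl group on the phenyl ring of 4-phenylpiperazin-1-yl would change the read-out as the methyl group did in the step to compound 2, and these single-concentration numbers do not give a potency for any of the compounds.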